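Adding a second chloro to compound 2

This account rests on a few compounds, and the source may have more. Where it says the series, first, only, none or still open, it means among the compounds named here.

Growth inhibition values in a functional assay on SW-620 cells (Homo sapiens); on this read-out higher numbers stand for weaker inhibition of growth and lower numbers for stronger inhibition of growth
Compound 1 `O=S(=O)(/C=C/c1ccc(F)cc1)Cc1ccc(Nc2ncnc3ccccc23)cc1` gives 100000 nM
Compound 2 `O=S(=O)(/C=C/c1ccc(Cl)cc1)Cc1ccc(Nc2ncnc3ccccc23)cc1` gives 77000 nM

On these numbers, compound 2 lies within the scatter of compound 1, so the two cannot be ranked. The next compound to be measured is compound 3 `O=S(=O)(/C=C/c1ccc(Cl)cc1Cl)Cc1ccc(Nc2ncnc3ccccc23)cc1`, and its difference from compound 2 is chloro in place of hydrogen on an aromatic carbon. This takes 4-chlorophenyl to 2,4-dichlorophenyl. Within the data shown here, only one measured step bears on this change, a 1.3-fold lower number from compound 1 to compound 2 (0.11 log units; within the scatter), and it stays within the scatter. Among the measured compounds shown here, that step exchanges fluoro for chloro rather than adding a group, so it is indirect evidence, and no measured step shows chloro in place of hydrogen. No shift beyond the scatter is therefore expected in this assay. The expected change is a 1.2-fold lower number from compound 2 to compound 3 (0.07 log units; within the scatter). For compound 3 the estimated value is 65000 nM, within an expected range from 30000 nM to 100000 nM.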

Compound 3, concentration for 50% growth inhibition: 14000 nM
Compound 3: the middle estimate sits 4.6-fold (0.67 log units) above what was measured; the measured number lies below the stated range.
By their numbers in this assay, from the lowest: compound 3; then compounds 2 and 1 (each within the scatter of the next).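

In this assay, among these compounds, chloro in place of hydrogen on an aromatic carbon ortho to a large group gives a 5.5-fold lower number from compound 2 to compound 3 (0.74 log units; beyond the scatter) and is the first change here to move the number beyond the scatter, whereas chloro in place of fluoro alone had not done so. Measured against the fluoro end of the series, 2,4-dichlorophenyl in place of 4-fluorophenyl gives a 7.1-fold lower number from compound 1 to compound 3 (0.85 log units; beyond the scatter) and shows that this aromatic ring can respond to substitution, with the added chloro accounting for most of the step. Nothing measured here offers a reason for this shift.

From the compounds shown here alone, whether this position needs chloro in particular stays open, since a methyl, a methoxy or an amine on the same carbon could give a different step. Also open, going by these compounds, is whether the step depends on the chloro group already on the ring, or whether the same change would hold with fluoro in its place.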